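From pyrrolidin-1-yl to 1H-pyrrol-1-yl in compound 4

A few compounds are considered here, and "the series" means these few. Any claim that something is new, unique, unknown or untested is made for them only; others in the source may bear on it.

Measured in a physicochemical assay for lipophilicity, at pH 7.4; on this read-out lower numbers stand for lower lipophilicity and higher numbers for higher lipophilicity:
- compound 1 `CCOc1cc(Cl)c(C(=O)NC(=O)Nc2nc3ccc(S(=O)(=O)C4CCN(C)CC4)cc3s2)cc1-n1cccn1`: 3
- compound 2 `CN1CCC(S(=O)(=O)c2ccc3nc(NC(=O)NC(=O)c4cc(-n5cccn5)c(F)cc4Cl)sc3c2)CC1`: 2.4
- compound 3 `CCOc1cc(Cl)c(C(=O)NC(=O)Nc2nc3ccc(CN4CCN(C)CC4)cc3s2)cc1N1CCCC1`: 4

Of these three, compound 3 stands highest at 4. Compound 4 `CCOc1cc(Cl)c(C(=O)NC(=O)Nc2nc3ccc(CN4CCN(C)CC4)cc3s2)cc1-n1cccc1` carries 1H-pyrrol-1-yl in place of pyrrolidin-1-yl on an aromatic carbon. Among the compounds with values here, no measured step covers this exchange. The only one available, a number 0.60 log units lower from compound 1 to compound 2 (beyond the scatter), is fluoro in place of ethoxy, a different change, so it serves only as a rough gauge of size. On this assay, only a small downward move, not clearly beyond the scatter, is therefore expected, and the estimated step is a number 0.10 log units lower from compound 3 to compound 4 (within the scatter). For compound 4 the expected value is 3.9, with an estimated range from 3.4 to 4.4.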

Compound 4, distribution coefficient: 4
Estimate against measurement, compound 4: 0.10 log units below, within the range that was stated.
By their numbers in this assay, from the lowest: compound 2; then compound 1; then compounds 3 and 4 (each within the scatter of the next).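

Replacing pyrrolidin-1-yl with 1H-pyrrol-1-yl, ortho to the ethoxy group, gives in this assay no change at the digits printed from compound 3 to compound 4 (within the scatter). This shows that, for this pair, the read-out does not separate the non-aromatic ring from the aromatic one at this position, which the earlier step, fluoro in place of ethoxy, could not show. No measurement shown accounts for this result. Still open, going by these compounds, is whether an open-chain amine such as dimethylamino or a carboxylic acid at this position would shift the number, and whether the same exchange would behave alike with fluoro in place of ethoxy.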